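The source may hold more compounds than are shown below. What is called first, only, known or untested is meant among the compounds shown, and "the series" means these compounds.

Measured so far in a functional assay on CHO-K1 cells for antagonist activity at transient receptor potential cation channel subfamily V member 1 (Homo sapiens), read by FLIPR; on this read-out higher numbers stand for weaker inhibition and lower numbers for stronger inhibition:
compound 1 `CC(C(=O)NCc1ccc(C(F)(F)F)nc1NC1CCCCC1)c1ccc(NS(C)(=O)=O)c(F)c1` gives 260 nM
compound 2 `Cc1ccc(Cl)cc1Nc1nc(C(F)(F)F)ccc1CNC(=O)C(C)c1ccc(NS(C)(=O)=O)c(F)c1` gives 140 nM
compound 3 `CC(C(=O)NCc1ccc(C(F)(F)F)nc1N1CC=CCC1)c1ccc(NS(C)(=O)=O)c(F)c1` gives 12.1 nM

Compound 3 stands lowest of the three numbers in this assay; the step of a 12-fold lower number from compound 2 to compound 3 (1.06 log units; beyond the scatter) and the step of a 21-fold lower number from compound 1 to compound 3 (1.33 log units; beyond the scatter) are both beyond the scatter, so compound 3 is the strongest inhibitor of the measured set. The step of a 1.9-fold lower number from compound 1 to compound 2 (0.27 log units; within the scatter) is within the scatter and says nothing about order between compound 1 and compound 2.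

Compound 4 `CC(C(=O)NCc1ccc(C(F)(F)F)nc1N1CCC(c2ccccc2)CC1)c1ccc(NS(C)(=O)=O)c(F)c1` differs from compound 3 in one place: a group of 12 heavy atoms (11 carbon, 1 nitrogen; one six-membered non-aromatic ring with 1 hetero atom, one six-membered aromatic ring of carbon only) in place of a group of 6 heavy atoms (5 carbon, 1 nitrogen; one six-membered non-aromatic ring with 1 hetero atom), on an aromatic carbon. Among the compounds with values here, no measured step exchanges one six-membered non-aromatic ring with one hetero atom for another of that kind carrying a phenyl, so the change has no direct precedent. What bears on it is that the two groups replaced in the step from compound 1 and in the step from compound 2 were a cyclohexyl and a 5-chloro-2-methylphenyl, each of which gave a clearly higher number than the six-membered ring with the double bond in compound 3. The 4-phenylpiperidin-1-yl group of compound 4 lacks that double bond and is larger, so a higher number than compound 3, of moderate size, is expected in this assay. For compound 4 the expected result is 60 nM, range 15 nM to 250 nM, corresponding to an estimated step of a 5.0-fold higher number from compound 3 to compound 4 (0.70 log units; beyond the scatter).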

Compound 4, half-maximal inhibitory concentration: 25 nM
Beside the measured number, compound 4's estimate is 2.4-fold (0.38 log units) above it, and the stated range covers the measured number.
By their numbers in this assay, from the lowest: compound 3; then compound 4; then compounds 2 and 1 (each within the scatter of the next).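

In this assay, the aromatic carbon next to the ring nitrogen accepts the much larger 4-phenylpiperidin-1-yl group, which has no double bond outside aromatic rings, at only a modest cost (a 2.1-fold higher number from compound 3 to compound 4 (0.32 log units; beyond the scatter)). Within the data shown here, this group also stands well below both amino-linked groups (a 5.6-fold lower number from compound 2 to compound 4 (0.75 log units; beyond the scatter)) and (a 10-fold lower number from compound 1 to compound 4 (1.02 log units; beyond the scatter)), so the low numbers are not confined to the small ring of compound 3: across the four compounds, the two groups joined through a ring nitrogen give lower numbers than cyclohexylamino and (5-chloro-2-methylphenyl)amino, and no compound here goes against this. Nothing measured here accounts for these steps.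

Still open, from the compounds shown here alone, is how the number responds to a morpholine ring or an open-chain diethylamino group at this carbon, or to a hydroxyl, an amine or a carboxylic acid on the phenyl ring of 4-phenylpiperidin-1-yl. Also open, going by these compounds, is how much of the step between the two ring-nitrogen-linked compounds belongs to the added phenyl and how much to the missing double bond, a question that plain piperidin-1-yl or 4-phenyl-substituted tetrahydropyridine would address.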